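A few compounds are considered here, and "the series" means these few. Any claim that something is new, unique, unknown or untested is made for them only; others in the source may bear on it.

The measured compounds:
compound 1, `CCC1=C(O)c2c(oc(-c3cccc(F)c3)cc2=O)C(CC)(CC)C1=O`, which reaches only a limit in a functional assay on KB cells (Homo sapiens) for antiproliferative activity, read by sulforhodamine B assay, with a stated time of 3 days; on this read-out higher numbers stand for an effect only at larger amounts of compound and lower numbers for an effect already at smaller amounts: > 56.2 uM.
compound 2, `CCC1=C(O)c2c(oc(-c3ccc(C)cc3C)cc2=O)C(CC)(CC)C1=O`, in this assay: 41.2 uM.
compound 3, `CCC1=C(O)c2c(oc(-c3ccc(C)c(C)c3)cc2=O)C(CC)(CC)C1=O`, in this assay: 35.5 uM.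

Compound 3 holds the lowest of the two numbers, but its nearest neighbour, compound 2, sits within the scatter: a 1.2-fold lower number from compound 2 to compound 3 (0.06 log units; within the scatter). The remaining value is a limit, not a number. Compound 4, `CCC1=C(O)c2c(oc(-c3cc(C)ccc3F)cc2=O)C(CC)(CC)C1=O`, differs from compound 3 in one place: 2-fluoro-5-methylphenyl in place of 3,4-dimethylphenyl on an aromatic carbon. Going by the values given here, two measured steps bear on this change. Replacing the 3-fluorophenyl of compound 1 with a dimethylphenyl gave an at least 1.5-fold lower number from compound 1 to compound 3 (0.19 log units; that floor lies within the scatter) and an at least 1.3-fold lower number from compound 1 to compound 2 (0.13 log units; that floor lies within the scatter), each of them only a floor due to the limit of > 56.2 uM in this assay, at which 1 of the 3 values shown sits. The step to compound 4 moves part of the way back, trading one methyl for a fluorine, so a somewhat higher number is expected, perhaps again ending at a limit; the estimated step is a 1.4-fold higher number from compound 3 to compound 4 (0.15 log units; within the scatter). Compound 4 is therefore expected to give 50 uM, with a range from 25 uM to 100 uM.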

Compound 4, concentration for half-maximal effect: 47.3 uM
Compound 4: the middle estimate sits 1.1-fold (0.02 log units) above what was measured; the measured number falls inside the stated range.
By their numbers in this assay, from the lowest: compounds 3, 2 and 4 (each within the scatter of the next). At a limit, above all of these: compound 1.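

In this assay, the 2-fluoro-5-methylphenyl group at this position, next to the ring oxygen, cannot be told apart from either dimethylphenyl group: a 1.3-fold higher number from compound 3 to compound 4 (0.12 log units; within the scatter) and a 1.1-fold higher number from compound 2 to compound 4 (0.06 log units; within the scatter). Compound 1 stands at a limit, yet compound 4, which also carries a fluorine on its phenyl group, gives a number, so among these compounds a fluorine there does not always end at a limit. Against the 3-fluorophenyl group there is an at least 1.1-fold lower number from compound 1 to compound 4 (0.07 log units; that floor lies within the scatter), and the true size of that step stays open, due to what bounds it: the limit of > 56.2 uM in this assay, at which 1 of the 4 values shown sits.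

All four compounds carry only methyl and fluorine on this phenyl group. From the compounds shown here alone, whether an amine, a carboxylic acid or a methoxy group there would move the number beyond the scatter remains open.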